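This account rests on a few compounds, and the source may have more. Where it says the series, first, only, none or still open, it means among the compounds named here.

For the measured compounds named here, compound 1 `COc1cccc(/C=C2\CCC/C(=C\c3cccc(OC)c3OC)C2=O)c1` gives 7000 nM in a functional assay on SW-620 cells (Homo sapiens) for cytotoxicity, read by MTT assay, with a stated time of 72 h (on this read-out higher numbers stand for weaker inhibition and lower numbers for stronger inhibition), the highest of the three numbers so far. Compound 2 `COc1cc(/C=C2\CCC/C(=C\c3cccc(OC)c3OC)C2=O)cc(OC)c1` gives 3800 nM, and compound 3 `COc1cccc(/C=C2\CCC/C(=C\c3cc(OC)c(OC)c(OC)c3)C2=O)c1OC` gives 2500 nM; the step of a 1.8-fold lower number from compound 1 to compound 2 (0.27 log units; within the scatter) lies within the scatter, while compound 3 stands beyond the scatter from compound 1.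

Compound 4 `COc1cc(/C=C2\CCC/C(=C\c3cccc(OC)c3OC)C2=O)ccc1O` differs from compound 1 by hydroxy in place of hydrogen on an aromatic carbon. The two measured steps, a 1.8-fold lower number from compound 1 to compound 2 (0.27 log units; within the scatter) and a 1.5-fold lower number from compound 2 to compound 3 (0.18 log units; within the scatter), both added a methoxy rather than a hydroxy and both stayed within the scatter, so they bear only loosely on this change. No step beyond the scatter is therefore expected, with a slight lean toward a lower number.

Compound 4 is estimated at 5000 nM, within 2500 nM to 10000 nM, which would mean a step of a 1.4-fold lower number from compound 1 to compound 4 (0.15 log units; within the scatter) expected from compound 1.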

Compound 4, half-maximal inhibitory concentration: 8600 nM
Beside the measured number, compound 4's estimate is 1.7-fold (0.24 log units) below it, within the range that was stated.
By their numbers in this assay, from the lowest: compounds 3, 2, 1 and 4 (each within the scatter of the next, the first and the last beyond it).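

Hydroxy in place of hydrogen, on the aromatic carbon ortho to a methoxy group and para to a large group, gives a 1.2-fold higher number from compound 1 to compound 4 (0.09 log units; within the scatter) in this assay. The change from 3-methoxyphenyl to 4-hydroxy-3-methoxyphenyl therefore adds a hydrogen-bond donor at this position without a step beyond the scatter. No measurement here bears on why the step is this small.

From the compounds shown here alone, whether an amine or a carboxylic acid on this same carbon would give a step beyond the scatter remains open. The compounds shown also leave open how a lone methoxy there would compare with the hydroxy of compound 4.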